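The source may hold more compounds than are shown below. What is called first, only, known or untested is meant among the compounds shown, and "the series" means these compounds.

Among the compounds with values here, in a functional assay on P388 cells (Mus musculus) for cytotoxicity (on this read-out higher numbers stand for weaker inhibition and lower numbers for stronger inhibition), compound 1 `COC(=O)CC[C@@H]1NC(=O)[C@@H](C)NC(=O)[C@@H]2Cc3ccc(OC)c(c3)Oc3ccc(cc3)C[C@@H](C(=O)N2C)N(C)C(=O)[C@H](C)NC(=O)[C@H](Cc2ccc(OC)cc2)N(C)C1=O` gives 58.9 nM and compound 2 `COc1ccc(C[C@H]2C(=O)N[C@@H](C)C(=O)N(C)[C@H]3Cc4ccc(cc4)Oc4cc(ccc4OC)C[C@@H](C(=O)N[C@H](C)C(=O)N[C@@H](CS)C(=O)N2C)N(C)C3=O)cc1` gives 363 nM, so compound 2 holds the higher of the two numbers measured so far. Compound 3 `C=CC[C@@H]1NC(=O)[C@@H](C)NC(=O)[C@@H]2Cc3ccc(OC)c(c3)Oc3ccc(cc3)C[C@@H](C(=O)N2C)N(C)C(=O)[C@H](C)NC(=O)[C@H](Cc2ccc(OC)cc2)N(C)C1=O` has vinyl in place of sulfanyl on a saturated chain carbon bound to a saturated ring carbon. Within the data shown here, one measured step bears on this change, a 6.2-fold higher number from compound 1 to compound 2 (0.79 log units; beyond the scatter). It is modest, lies beyond the scatter and brought sulfanyl onto the same kind of carbon in place of (methoxycarbonyl)methyl. Among the measured compounds shown here, no measured compound carries vinyl, so this is indirect evidence only. On the basis of a 6.2-fold higher number from compound 1 to compound 2 (0.79 log units; beyond the scatter), losing sulfanyl is expected to give a modest move to a lower number in this assay, though a result within the scatter would remain possible. The estimated change is a 3.0-fold lower number from compound 2 to compound 3 (0.48 log units; beyond the scatter). For compound 3 the expected value is 120 nM, with an estimated range of 35 nM to 420 nM.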

Compound 3, half-maximal inhibitory concentration: 38.9 nM
The estimate for compound 3 lay 3.1-fold (0.49 log units) above the measured number; the range from low to high includes it.
By their numbers in this assay, from the lowest: compounds 3 and 1 (each within the scatter of the next); then compound 2.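

In this assay, the saturated chain carbon bound to a saturated ring carbon now has two groups that cannot be told apart: vinyl in place of (methoxycarbonyl)methyl gives a 1.5-fold lower number from compound 1 to compound 3 (0.18 log units; within the scatter), so these two very different groups leave the number unchanged within the scatter. Vinyl in place of sulfanyl gives a 9.3-fold lower number from compound 2 to compound 3 (0.97 log units; beyond the scatter), which makes sulfanyl the only one of the three groups set apart, with both of its steps beyond the scatter. Nothing on hand gives a cause for the sulfanyl result.

Still open, going by these compounds, is whether the separation belongs to sulfur itself, which a hydroxyl or a methylthio group at this place would test. An amine, a carboxylic acid or a longer alkyl chain would show whether the number stays with compound 1 and compound 3 or moves towards compound 2.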